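From fluoro to dimethylamino in a cytotoxicity test

A few compounds are considered here, and "the series" means these few. Any claim that something is new, unique, unknown or untested is made for them only; others in the source may bear on it.

In an ADME assay on KB cells (Homo sapiens) for cytotoxicity, read by MTT assay, with a stated time of 72 h (on this read-out lower numbers stand for higher toxicity in this test and higher numbers for lower toxicity in this test), compound 1 `COc1ccc(Nc2nc(-c3ccccn3)cs2)cc1` gives 140000 nM as its reading. Compound 2 `Fc1ccc(Nc2nc(-c3ccccn3)cs2)cc1` has no number, its entry being "not determined" (no result reported) in this test, so it offers no starting point for comparison. Compound 3 `CN(C)c1ccc(Nc2nc(-c3ccccn3)cs2)cc1` still awaits measurement. The change dimethylamino in place of fluoro on an aromatic carbon puts dimethylamino in place of fluoro on an aromatic carbon. With only compound 1 at 140000 nM as a guide, a small step toward lower numbers in this assay is expected, meaning slightly higher toxicity. Compound 3 is estimated to read about 70000 nM (range 15000 nM to 250000 nM).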

Compound 3, half-maximal cytotoxic concentration: > 400000 nM
Compound 3 was reported as a limit (the forecaster's own chance of this, stated with the estimate: 25%); middle value at least 5.7-fold (0.75 log units) from the limit.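

At this place on the ring, dimethylamino in place of methoxy moves the reading in this assay clearly upward, with an at least 2.8-fold higher number from compound 1 to compound 3 (0.45 log units; beyond the scatter), which points to lower toxicity in this test. Compound 3 gives > 400000 nM, which is a limit and not a number: the limit of > 400000 nM in this assay, at which 1 of the 3 values shown sits. The step from fluoro to dimethylamino cannot be read, since compound 2 has no result.

On these data alone, how far compound 3 lies past its limit stays open. So does the reading that a smaller amine, such as methylamino, or a carboxylic acid would give at this same place.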